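The compounds below may be only part of what the source reports. "The series", "measured", "known", "first", "only" and "open" are said of these compounds alone.

Of the compounds shown here, two have been measured so far in a functional assay on HT-29 cells (Homo sapiens) for inhibition, read by MTT assay, with a stated time of 48 h; a lower number here means a stronger inhibitor, a higher number a weaker inhibitor. Among the compounds with values here, compound 2 `COc1cc(/C=C/c2ccc(NC(=O)/C=C/c3cccc(F)c3)cc2)cc(OC)c1` gives 16800 nM, and its only neighbour, compound 1 `COc1cc(/C=C/c2ccc(NC(=O)/C=C/c3ccc(F)cc3)cc2)cc(OC)c1`, gives 11600 nM; the step of a 1.4-fold higher number from compound 1 to compound 2 (0.16 log units; within the scatter) shows that these two numbers sit within the scatter of each other, so neither can be called stronger or weaker than the other. Compound 3 `COc1cc(/C=C/c2ccc(NC(=O)/C=C/c3ccccc3F)cc2)cc(OC)c1` has not yet been measured. It differs from compound 2 in one place: 2-fluorophenyl in place of 3-fluorophenyl on a double-bonded chain carbon bound to a double-bonded chain carbon. Within the data shown here, the one measured step that bears on this change, swapping one fluorophenyl for another on the same chain carbon, is a 1.4-fold higher number from compound 1 to compound 2 (0.16 log units; within the scatter), which stayed within the scatter. On that basis no shift beyond the scatter is expected in this assay, in either direction, and compound 3 is estimated at 14000 nM, within a range from 6000 nM to 35000 nM, a step of a 1.2-fold lower number from compound 2 to compound 3 (0.08 log units; within the scatter).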

Compound 3, half-maximal inhibitory concentration: 2820 nM
For compound 3 the middle estimate is 5.0-fold (0.70 log units) above the measured one, outside the stated range (below it).
By their numbers in this assay, from the lowest: compound 3; then compounds 1 and 2 (each within the scatter of the next).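

In this assay the place of the fluorine on this ring now matters, which the earlier pair did not show: 2-fluorophenyl gives a 6.0-fold lower number from compound 2 to compound 3 (0.78 log units; beyond the scatter) and a 4.1-fold lower number from compound 1 to compound 3 (0.61 log units; beyond the scatter) and both steps lie beyond the scatter, so compound 3 is the strongest inhibitor of the three. The change neither adds nor removes any atom, so a group with the same atoms and the same counts can still shift the result, while 3-fluorophenyl and 4-fluorophenyl stay within the scatter of each other. Nothing given here explains why 2-fluorophenyl stands apart.

As far as these compounds go, it remains open whether chlorine or a methoxy group in the place of this fluorine would behave like compound 3. A plain phenyl group is also missing from these compounds, so it is unclear whether the fluorine in compound 3 strengthens inhibition or those in compound 1 and compound 2 weaken it.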